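Replacing 4-methylpiperazin-1-yl with sulfamoyl on a weak inhibitor

This account rests on a few compounds, and the source may have more. Where it says the series, first, only, none or still open, it means among the compounds named here.

Of the compounds shown here, two that share a core have been measured in a functional assay on HT-29 cells (Homo sapiens) for antiproliferative activity, read by MTT assay; a lower number here means a stronger inhibitor, a higher number a weaker inhibitor. Compound 1 `CN1CCN(c2ccc(Nc3ncc(/N=C/c4ccc(C(F)(F)F)cc4)c(NC4CCCC4)n3)cc2)CC1` gives 80700 nM in this assay. Compound 2 `CC(C)Nc1nc(Nc2ccc(N3CCN(C)CC3)cc2)ncc1/N=C/c1ccc(C(F)(F)F)cc1` reaches only a limit of this assay, > 100000 nM, so no number is known for it. This limit is the limit of > 100000 nM in this assay, at which 1 of the 2 values shown sits. Among the compounds with values here, the only measured step, an at least 1.2-fold higher number from compound 1 to compound 2 (0.09 log units; that floor lies within the scatter), sits at a floor that lies within the usual scatter, so compound 1 and compound 2 cannot be told apart on these data.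

Compound 3 `CC(C)Nc1nc(Nc2ccc(S(N)(=O)=O)cc2)ncc1/N=C/c1ccc(C(F)(F)F)cc1` differs from compound 2 by sulfamoyl in place of 4-methylpiperazin-1-yl on an aromatic carbon. Within the data shown here, no measured step touches this part of the molecule, since the one step known concerns a different attachment point, so it cannot be carried over to this change. There is therefore no basis for expecting a step in this assay in either direction beyond the scatter.

On that footing compound 3 is expected to stay near the level of compound 2, at an estimated 70000 nM with a range from 15000 nM to 200000 nM. The expected step is an at least 1.4-fold lower number from compound 2 to compound 3 (0.15 log units; that floor lies within the scatter), with a real chance that only a limit is reported again.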

Compound 3, half-maximal inhibitory concentration: > 100000 nM
Compound 3 was reported as a limit; the forecaster's own chance of this, stated with the estimate: 50%; at least 1.4-fold (0.15 log units) between middle value and limit.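

Compound 2 and compound 3 each reach only a limit in this assay, so no step between them can be read, and the two cannot be ranked: the limit of > 100000 nM in this assay, at which 2 of the 3 values shown sit.

Left open is whether sulfamoyl in place of 4-methylpiperazin-1-yl moves the number in this assay in either direction, and by how much.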